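The source may report more compounds than this note shows. Statements on the series, on what has been measured and on what is new or still open speak of the compounds shown alone.

Compound 1 `CC(C)(C)c1ccc([N+](C)(C)CCCNc2cc(Cl)ccc2Sc2ccccc2)cc1` gives 2.14 ug/mL in a functional assay on KB cells (Homo sapiens) for cytotoxicity; a higher number here means a weaker inhibitor, a lower number a stronger inhibitor. Compound 2 `CCCC(=O)Nc1cc(Cl)ccc1Sc1ccccc1` is an amide on the same core. In this assay compound 2 reaches only the limit of the assay, > 300 ug/mL, so it gives no number and its standing rests on the limit of > 300 ug/mL in this assay, at which 1 of the 2 values shown sits, alone. Compound 3 `O=C(Nc1cc(Cl)ccc1Sc1ccccc1)c1ccccc1` differs from compound 2 by phenyl in place of propyl on a carbonyl carbon. With compound 2 at the limit, the step of a number no higher from compound 2 to compound 3 (the limit leaves the size open) is expected to be small, in no direction beyond the scatter. Compound 3 is estimated at 300 ug/mL, between 100 ug/mL and 1000 ug/mL, most likely reported again as a limit.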

Compound 3, half-maximal inhibitory concentration: 9 ug/mL
The estimate for compound 3 lay 33-fold (1.52 log units) above the measured number; the whole stated range lies above it.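

Within this assay the carbonyl carbon of the amide responds strongly to its substituent: phenyl in place of propyl gives an at least 33-fold lower number from compound 2 to compound 3 (1.52 log units; beyond the scatter) on the shared core. Compound 3 has no net charge, so a measured number on this core does not depend on carrying one. From the compounds shown here alone, the true size of the step stays unknown because compound 2 stands at a limit: the limit of > 300 ug/mL in this assay, at which 1 of the 3 values shown sits.

The compounds shown do not separate the aromatic ring from the carbon count, since neither a cyclohexyl group nor a longer chain stands on this carbonyl carbon. Substituted phenyl rings, such as one bearing an amine or a carboxylic acid, also remain open.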